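The source may hold more compounds than are shown below. What is called first, only, known or untested is meant among the compounds shown, and "the series" means these compounds.

Working notes on the series. The shared core carries a variable aromatic group on an aromatic carbon; compound 1 `O=C(CCCCCCc1ccccc1)c1ncc(-c2ccccc2F)o1` gives 110 nM in an assay (Rattus norvegicus) for inhibition of Fatty-acid amide hydrolase 1 (Homo sapiens); on this read-out lower numbers stand for stronger inhibition and higher numbers for weaker inhibition. Compound 2 `NC(=O)c1cccc(-c2cnc(C(=O)CCCCCCc3ccccc3)o2)c1` gives 6 nM in this assay. Compound 3 `COc1ccnc(-c2cnc(C(=O)CCCCCCc3ccccc3)o2)c1` gives 0.8 nM in this assay, the lowest of the three numbers. Both steps onto its aromatic group were downward and beyond the scatter: a 140-fold lower number from compound 1 to compound 3 (2.14 log units; beyond the scatter) and a 7.5-fold lower number from compound 2 to compound 3 (0.88 log units; beyond the scatter). Compound 4 `O=C(CCCCCCc1ccccc1)c1ncc(-c2cncnc2)o1` carries pyrimidin-5-yl in place of 4-methoxypyridin-2-yl on an aromatic carbon. Since the 4-methoxypyridin-2-yl accounts for the largest gains seen, its removal is expected to give back part of them, an upward step a 10-fold higher number from compound 3 to compound 4 (1.00 log units; beyond the scatter) in this assay. Compound 4 is therefore estimated at 8 nM, with a range from 1.5 nM to 40 nM.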

Compound 4, inhibition constant: 22 nM
Compound 4: middle estimate off by 2.8-fold (0.44 log units), on the low side, and the stated range covers the measured number.
By their numbers in this assay, from the lowest: compound 3; then compound 2; then compound 4; then compound 1.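

In this assay, pyrimidin-5-yl does not match the best group at this position: a 28-fold higher number from compound 3 to compound 4 (1.44 log units; beyond the scatter), and a 3.7-fold higher number from compound 2 to compound 4 (0.56 log units; beyond the scatter). It still improves on 2-fluorophenyl, with a 5.0-fold lower number from compound 1 to compound 4 (0.70 log units; beyond the scatter), so a six-membered aromatic ring with 2 hetero atoms keeps part of the gain without any carbamoyl or methoxy group. Nothing available here explains this order of groups. From the compounds shown here alone, it remains open whether the methoxy group or the ring of 4-methoxypyridin-2-yl carries the low number of compound 3. Unsubstituted pyridin-2-yl, or an amine or carboxylic acid on the pyrimidine ring, would extend the comparison.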